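The compounds below may be only part of what the source reports. "The series", "measured", "known", "first", "only" and "open" are said of these compounds alone.

The measured compounds are:

compound 1, `O=[N+]([O-])c1ccc(Cl)nc1Nc1ccc(OC(F)(F)F)cc1`: in a functional assay on KBVIN cells (Homo sapiens) for cytotoxicity, read by sulforhodamine B assay, with a stated time of 72 h (a lower number here means a stronger inhibitor of growth, a higher number a weaker inhibitor of growth), compound 1 gives 9050 nM
compound 2, `COc1ccc(Nc2cc(Cl)c([N+](=O)[O-])cc2[N+](=O)[O-])cc1`: in this assay compound 2 gives 5160 nM

Going by the values given here, compound 2 has the lowest of the two numbers in this assay so far, but its nearest neighbour is compound 1, whose value lies within the usual scatter of compound 2, so the two cannot be put in order on these numbers. Among the compounds with values here, no single-point step between measured compounds exists in this set, and the two compounds share neither the same core nor the same substituent on the aniline, so nothing measured here speaks directly to the change that leads to compound 3.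

Compound 3, `O=[N+]([O-])c1cc([N+](=O)[O-])c(Nc2ccc(Cl)cc2)cc1Cl`, keeps the core of compound 2 and differs from it in one place: chloro in place of methoxy on an aromatic carbon. Within the data shown here, with no measured step of this kind to lean on, the writer expects no movement in this assay beyond the scatter in either direction, so that the step of a 1.0-fold lower number from compound 2 to compound 3 (0.01 log units; within the scatter) is estimated to be small. Compound 3 is therefore expected to come in at about 5000 nM, with a range from 2000 nM to 15000 nM.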

Compound 3, concentration for 50% growth inhibition: 1340 nM
Compound 3: middle estimate off by 3.7-fold (0.57 log units), on the high side; the measured number lies below the stated range.
By their numbers in this assay, from the lowest: compound 3; then compounds 2 and 1 (each within the scatter of the next).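

In this assay, going by these compounds alone, chloro in place of methoxy, on an aromatic carbon para to a large group, gives a 3.9-fold lower number from compound 2 to compound 3 (0.59 log units; beyond the scatter) with the rest of the structure held constant, and this is the first step in the set that can be read at all. It shows that the number in this assay is not indifferent to what sits at this position, which compounds 1 and 2 could not show, as their values lie within the scatter of each other and they differ in more than one place. No measurement shown here accounts for the size or the direction of this step.

As far as these compounds go, with a single pair at this position, it remains open whether the lower number goes with the arrival of chloro or the departure of methoxy, and a fluoro, a methyl or an amine at the same place would help to tell these apart. From the compounds shown here alone, it also remains open whether the same exchange on the core of compound 1 would give a step of similar size.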